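This account rests on a few compounds, and the source may have more. Where it says the series, first, only, none or still open, it means among the compounds named here.

Three compounds sharing one core have been run in a functional assay on NCI-H1975 cells (Homo sapiens) for antiproliferative activity, read by MTT assay, with a stated time of 72 h; a lower number here means a stronger inhibitor, a higher number a weaker inhibitor. Compound 1 `COc1cc2ncnc(Nc3ccc(Cl)c(C(F)(F)F)c3)c2cc1OCCCCC(=O)Nc1ccc(S(N)(=O)=O)cc1` gives 3220 nM. Compound 2 `COc1cc2ncnc(Nc3ccc(Br)cc3)c2cc1OCCCCC(=O)Nc1ccc(S(N)(=O)=O)cc1` gives 23300 nM. Compound 3 `COc1ccc(Nc2ncnc3cc(OC)c(OCCCCC(=O)Nc4ccc(S(N)(=O)=O)cc4)cc23)cc1` gives 30200 nM, the highest of the three numbers; its nearest neighbour is compound 2, within the scatter, and its furthest is compound 1, whose step a 9.4-fold higher number from compound 1 to compound 3 (0.97 log units; beyond the scatter) lies beyond the scatter, as does a 7.2-fold higher number from compound 1 to compound 2 (0.86 log units; beyond the scatter). The step of a 1.3-fold higher number from compound 2 to compound 3 (0.11 log units; within the scatter) is within the scatter.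

Compound 4 `COc1cc2ncnc(Nc3ccc(OC(F)(F)F)cc3)c2cc1OCCCCC(=O)Nc1ccc(S(N)(=O)=O)cc1` differs from compound 3 by trifluoromethyl in place of methyl on an oxygen on an aromatic ring. For the measured compounds named here, no measured step changes that oxygen-bound group; the only step touching this ring position, from compound 2 to compound 3, stayed within the scatter, while the two steps beyond the scatter both involve the differently substituted ring of compound 1. The step of a 1.5-fold lower number from compound 3 to compound 4 (0.18 log units; within the scatter) is therefore expected to stay small and its direction is uncertain. Compound 4 is estimated at 20000 nM in this assay, within 6000 nM to 60000 nM.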

Compound 4, half-maximal inhibitory concentration: 8770 nM
Beside the measured number, compound 4's estimate is 2.3-fold (0.36 log units) above it, within the range that was stated.
By their numbers in this assay, from the lowest: compound 1; then compound 4; then compounds 2 and 3 (each within the scatter of the next).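

In this assay, trifluoromethyl in place of methyl on the oxygen gives a 3.4-fold lower number from compound 3 to compound 4 (0.54 log units; beyond the scatter), so a change at this ring position now goes beyond the scatter, whereas a 1.3-fold higher number from compound 2 to compound 3 (0.11 log units; within the scatter) had stayed within it. Trifluoromethoxy in place of bromo points the same way, with a 2.7-fold lower number from compound 2 to compound 4 (0.42 log units; beyond the scatter), which sets compound 4 apart from both compound 2 and compound 3. The gain does not close the gap to the ring of compound 1, as a 2.7-fold higher number from compound 1 to compound 4 (0.44 log units; beyond the scatter) shows that 4-(trifluoromethoxy)phenyl still falls short of 4-chloro-3-(trifluoromethyl)phenyl.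

On these data alone, whether a nitrile, an amine or a longer chain on the oxygen in place of methyl would follow compound 4 or compound 3 remains open. Nothing at hand explains why this change moves the number.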